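Replacing the methyl-bearing ring with a methoxy-bearing ring

The source may hold more compounds than are shown below. What is called first, only, known or untested is meant among the compounds shown, and "the series" means these compounds.

Measured compounds in an assay on cells for agonist activity at ecdysone receptor (Bombyx mori), read by a luciferase reporter, with a stated time of 24 h; a lower number here means that less compound is needed, a higher number that more compound is needed for the effect:
compound 1 `CC(C)(C)N(NC(=O)c1ccccc1)C(=O)c1ccccc1F`: 309 nM
compound 2 `CC(C)(C)N(NC(=O)c1ccccc1)C(=O)c1ccccc1Br`: 170 nM
compound 3 `Cc1ccccc1C(=O)NN(C(=O)c1ccccc1Cl)C(C)(C)C`: 72.4 nM

Compound 3 gives the lowest number of the three in this assay; its nearest neighbour is compound 2, and the gap to compound 1 is wider still, both beyond the scatter. Within the data shown here, the only one-change step among the measured compounds, a 1.8-fold lower number from compound 1 to compound 2 (0.26 log units; within the scatter), concerns the halogen-bearing ring and stays within the scatter.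

Compound 4 `COc1cccc(C(=O)NN(C(=O)c2ccccc2Cl)C(C)(C)C)c1` differs from compound 3 by 3-methoxyphenyl in place of 2-methylphenyl on a carbonyl carbon. Among the measured compounds shown here, no measured step touches this ring, so nothing among the measured compounds speaks directly to the size or direction of the step. The measured step on the other ring was small, which gives no reason to expect a large move here either.

Compound 4 is therefore expected to land near compound 3, at 130 nM, within a range of 35 nM to 500 nM, a change of a 1.8-fold higher number from compound 3 to compound 4 (0.25 log units; within the scatter) that is estimated to stay close to the scatter.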

Compound 4, half-maximal effective concentration: 52.5 nM
The estimate for compound 4 lay 2.5-fold (0.39 log units) above the measured number; the range from low to high includes it.
By their numbers in this assay, from the lowest: compounds 4 and 3 (each within the scatter of the next); then compounds 2 and 1 (each within the scatter of the next).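

In this assay, among these compounds, putting 3-methoxyphenyl in place of 2-methylphenyl on a carbonyl carbon gives a 1.4-fold lower number from compound 3 to compound 4 (0.14 log units; within the scatter), the first measured step on this ring, and it leaves the two compounds indistinguishable. This position therefore accepts a group with a different substituent and one more heavy atom, including a hydrogen-bond acceptor that 2-methylphenyl lacks, without a change that can be told from the scatter. Nothing available explains why the number holds across this swap.

Both the substituent and its place on the ring differ in this step, so the compounds shown cannot separate the two contributions. As far as these compounds go, whether this position would also accept an amine, a carboxylic acid or a longer chain such as butoxy remains open.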